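The compounds below may be only part of what the source reports. "The series", "measured", "known", "first", "only" and "open" are said of these compounds alone.

Measured compounds:
Compound 1, `C=CC(=O)N1C(=O)CC(c2ccc(C(F)(F)F)cc2)Sc2ccccc21`, gives 106000 nM.
Compound 2, `C=CC(=O)N1C(=O)CC(c2ccc(Cl)cc2)Sc2ccccc21`, gives 95700 nM.
Compound 3, `C=CC(=O)N1C(=O)CC(c2ccccc2Cl)Sc2ccccc21`, gives 91400 nM.

All three were tested in a functional assay on HL-60 cells (Homo sapiens) for cytotoxicity, read by CCK-8 assay, with a stated time of 24 h; a higher number here means a weaker inhibitor, a lower number a stronger inhibitor. The three numbers lie close together. Going a 1.1-fold higher number from compound 2 to compound 1 (0.04 log units; within the scatter), the change is trifluoromethyl in place of chloro on an aromatic carbon. Going a 1.0-fold lower number from compound 2 to compound 3 (0.02 log units; within the scatter), the cores of the two compounds differ as 2-chlorophenyl in place of 4-chlorophenyl on a saturated ring carbon. Neither step stands apart from the scatter, so no order among compounds 1, 2 and 3 can be read from these values.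

Compound 4, `C=CC(=O)N1C(=O)CC(c2ccccc2C(F)(F)F)Sc2ccccc21`, has not yet been measured in this assay . It differs from compound 3 by trifluoromethyl in place of chloro on an aromatic carbon. This is the same kind of change that was made from compound 2 to compound 1, but the place is not the same: in that earlier pair the group sits para to a large group, here it sits ortho to a large group. Because the earlier step of the same kind was a 1.1-fold higher number from compound 2 to compound 1 (0.04 log units; within the scatter), the step from compound 3 to compound 4 is expected to be similarly small, a 1.1-fold higher number from compound 3 to compound 4 (0.04 log units; within the scatter). Compound 4 is therefore estimated at 100000 nM, with a likely range from 60000 nM to 170000 nM.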

Compound 4, half-maximal inhibitory concentration: 96400 nM
Beside the measured number, compound 4's estimate is 1.0-fold (0.02 log units) above it, within the range that was stated.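

In this assay, trifluoromethyl in place of chloro, ortho to a large group, comes with a 1.1-fold higher number from compound 3 to compound 4 (0.02 log units; within the scatter), so compound 3 and compound 4 cannot be told apart. Set beside the same change where the group sits para to a large group, the new step does not differ from the earlier one: the same change on two cores in this assay, a 1.1-fold higher number (0.04 log units; within the scatter) from compound 2 to compound 1 and a 1.1-fold higher number (0.02 log units; within the scatter) from compound 3 to compound 4, 1.1-fold (0.02 log units) apart, within the scatter of two such steps The two cores therefore agree only in that neither shows a readable effect of this change, which does not establish an effect that carries from one core to another, and it says nothing about cores with clearly lower numbers.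

All four compounds shown carry either chloro or trifluoromethyl on the phenyl ring, and their numbers lie close together. Going by these compounds, it stays open whether an amine, a carboxylic acid or a methoxy group on that ring would give a number that stands apart from these, and whether this change would then leave a readable step.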